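A few compounds are considered here, and "the series" means these few. Any claim that something is new, unique, unknown or untested is made for them only; others in the source may bear on it.

Compound 1, `O=C(Nc1cc(-c2nc3ccccc3s2)ccc1Cl)c1cc([N+](=O)[O-])ccc1Cl`, gives in an ADME assay on BJ cells (Homo sapiens) for cytotoxicity, with a stated time of 72 h (on this read-out lower numbers stand for an effect already at smaller amounts and higher numbers for an effect only at larger amounts of compound), only a limit, > 25000 nM.
Compound 2, `O=C(Nc1cccc(-c2nc3ccccc3s2)c1)c1cc([N+](=O)[O-])c(O)cc1Cl`, gives in this assay only a limit, > 25000 nM.
Compound 3, `O=C(Nc1cccc(-c2nc3ccccc3s2)c1)c1cc([N+](=O)[O-])ccc1Cl`, gives in this assay only a limit, > 27000 nM.

None of the three measured compounds has a number in this assay; each reading is a limit. Compound 3 therefore stands nowhere in particular among the values shown: two of them sit at the limit of > 25000 nM in this assay, at which 2 of the 3 values shown sit, and one, that of compound 3 itself, at the limit of > 27000 nM in this assay, at which 1 of the 3 values shown sits.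

Compound 4 is `O=C(Nc1cccc(-c2ccccc2)c1)c1cc([N+](=O)[O-])ccc1Cl`. The change from compound 3 is phenyl in place of 1,3-benzothiazol-2-yl on an aromatic carbon.

Going by the values given here, two measured steps touch compound 3, and neither can be read in size. From compound 1 to compound 3 the step is a step that the two limits leave unreadable from compound 1 to compound 3, and from compound 2 to compound 3 it is a step that the two limits leave unreadable from compound 2 to compound 3. Nothing among these readings shows any change in this assay beyond the scatter, and no step shows the exchange of the 1,3-benzothiazol-2-yl group itself. The expected step from compound 3 to compound 4 is therefore a step that the limit leaves unreadable from compound 3 to compound 4, meaning no change that the measurement could resolve. Compound 4 is estimated at 30000 nM, with a range from 8000 nM to 100000 nM, and most likely it will again be reported only as a limit.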

Compound 4, half-maximal effective concentration: > 27000 nM
Compound 4 was reported as a limit; the forecaster's own chance of this, stated with the estimate: 80%; the middle value lies beyond the limit too.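

Compound 3 and compound 4 both appear only as limits in this assay, so the size of the step between them cannot be read. The compounds shown leave open at what amount any of them would show an effect, and so whether phenyl in place of 1,3-benzothiazol-2-yl changes anything.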